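A few compounds are considered here, and "the series" means these few. Any claim that something is new, unique, unknown or untested is made for them only; others in the source may bear on it.

Measured in a toxicity assay on NIH3T3 cells (Mus musculus) for cytotoxicity, read by resazurin assay; on this read-out higher numbers stand for an effect only at larger amounts of compound and lower numbers for an effect already at smaller amounts:
compound 1 `c1ccc(-c2ccc(Cn3cncc3CNc3ccc(-c4onc5ccccc45)c(-c4ccccc4)c3)cc2)cc1` gives > 10000 nM, a limit of the assay.
compound 2 `O=C(OC1CCCCC1)c1ccc(NCc2cncn2Cc2ccc(-c3ccccc3)cc2)cc1-c1ccccc1` gives > 10000 nM, a limit of the assay.
compound 3 `N#Cc1ccc(NCc2cncn2Cc2ccc(-c3ccccc3)cc2)cc1-c1ccccc1` gives > 1000 nM, a limit of the assay.

Compound 3 sits at the limit of > 1000 nM in this assay, at which 1 of the 3 values shown sits. Compounds 1 and 2 sit at the limit of > 10000 nM in this assay, at which 2 of the 3 values shown sit. Among the compounds with values here, none of the measured steps can be read as a size: a step that the two limits leave unreadable from compound 1 to compound 2, a step that the two limits leave unreadable from compound 1 to compound 3, a step that the two limits leave unreadable from compound 2 to compound 3. Compound 4 `c1ccc(-c2ccc(Cn3cncc3CNc3ccc(N4CCCCC4)c(-c4ccccc4)c3)cc2)cc1` differs from compound 3 by piperidin-1-yl in place of cyano on an aromatic carbon. Within the data shown here, no measured step bears on this exchange, and the measured steps themselves carry no size, so no direction or size beyond the scatter can be drawn for this assay. Among the measured compounds shown here, the expectation is only that compound 4, like the three measured compounds, shows no effect up to the limit. Compound 4 is estimated at 15000 nM, within 3000 nM to 60000 nM. The expected step is a step that the limit leaves unreadable from compound 3 to compound 4, most likely reported again as a limit.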

Compound 4, half-maximal effective concentration: > 1000 nM
Compound 4 ended at the assay's limit (the forecaster's own chance of this, stated with the estimate: 80%); the middle value is on the limit's open side.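

Compound 4, like compounds 1, 2 and 3, sits at a limit in this assay, so none of its steps to those compounds can be read. The compounds shown leave open whether exchanging these groups changes cytotoxicity at all, and at what concentration any compound takes effect.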